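This account rests on a few compounds, and the source may have more. Where it says the series, first, only, none or still open, it means among the compounds named here.

Three close relatives built on one shared core have been tested in a functional assay on the whole organism for inhibition, with Rattus norvegicus as the target, read by paw edema, in the formalin test, with a stated time of 1 h, at a dose of 100 mg/kg by the intraperitoneal route; on this read-out lower numbers stand for less inhibition and higher numbers for more inhibition at the one dose given (going by the name of the read-out). Compound 1 `O=c1cc(CNc2nc(-c3cc4cc(Br)cc(Br)c4oc3=O)cs2)c2cc(Cl)ccc2[nH]1` gives 13.8%. Compound 2 `O=c1cc(CNc2nc(-c3cc4cc(Br)cc(Br)c4oc3=O)cs2)c2ccc(Cl)cc2[nH]1` gives 12.6%, and compound 3 `Cc1cccc2c(CNc3nc(-c4cc5cc(Br)cc(Br)c5oc4=O)cs3)cc(=O)[nH]c12` gives 11.3%. On the bare numbers compound 1 sits at the top of the three, but the gap to compound 2 and the gap to compound 3 both lie within the scatter of repeated measurements, so the three compounds cannot be told apart on this read-out.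

Compound 4 `O=c1cc(CNc2nc(-c3cc4cc(Br)ccc4oc3=O)cs2)c2cc(Cl)ccc2[nH]1` has not yet been measured. It differs from compound 1 in one place: hydrogen in place of bromo on an aromatic carbon. Among the measured compounds no pair differs only in such a bromo group, so there is no measured step to lean on. Since all three measured compounds sit close together, the step in this assay is expected to be no larger than the scatter, in no particular direction. Compound 4 is thus expected to give 13%, with a likely range from 3% to 23%. The expected change a number 0.8 percentage points lower from compound 1 to compound 4 (within the scatter) is accordingly small.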

Compound 4, a percentage reported as inhibition, in the whole organism at one dose (the size of the read-out at that dose, not a potency): 4.42%
The estimate for compound 4 lay 8.6 percentage points above the measured number, within the range that was stated.
By their numbers in this assay, from the lowest: compounds 4, 3, 2 and 1 (each within the scatter of the next).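

Hydrogen in place of bromo on this aromatic carbon, ortho to a fused ring, gives a number 9.4 percentage points lower from compound 1 to compound 4 (within the scatter) in this assay. This is the first step shown at this position, and because it lies within the scatter, this single pair does not show that the bromo group here matters for the read-out. Nothing measured here bears on what lies behind the step.

From the compounds shown here alone, whether a methoxy group, an amine or a carboxylic acid on this carbon would give a number beyond the scatter from compound 1 remains open. Also open, going by these compounds, is what hydrogen in place of the other bromo group, the one meta to this position, would do, alone or with this change.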